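This account rests on a few compounds, and the source may have more. Where it says the series, first, only, none or still open, it means among the compounds named here.

Among the measured compounds shown here, compound 2, `CC1(C)CCC[C@]2(C)[C@@H](CC[C@@](C)(O)/C=C/c3ccc(Cl)nc3)[C@](C)(O)CC[C@@H]12`, gives 275 nM in a functional assay on PC-3 cells (Homo sapiens) for cytotoxicity, read by MTT assay, with a stated time of 48 h (a higher number here means a weaker inhibitor, a lower number a stronger inhibitor), the lowest of the two numbers measured so far. Compound 1, `Cc1cccc(/C=C/[C@](C)(O)CC[C@@H]2[C@@]3(C)CCCC(C)(C)[C@@H]3CC[C@@]2(C)O)c1C`, gives 3500 nM in this assay. For the measured compounds named here, the single step that joins them, a 13-fold lower number from compound 1 to compound 2 (1.10 log units; beyond the scatter), shows that exchanging the aromatic group on the double-bonded chain carbon can move the number a long way. Compound 3, `CC1(C)CCC[C@]2(C)[C@@H](CC[C@@](C)(O)/C=C/c3ccc(C(=O)O)cc3)[C@](C)(O)CC[C@@H]12`, carries a change at that same place: 4-carboxyphenyl in place of 6-chloropyridin-3-yl on a double-bonded chain carbon bound to a double-bonded chain carbon. Going by the values given here, the only measured step bearing on this change is a 13-fold lower number from compound 1 to compound 2 (1.10 log units; beyond the scatter), and while it marks this position as sensitive, it holds no information about a 4-carboxyphenyl group, so its direction cannot simply be carried over. A step of real size in either direction is therefore possible, with a move toward a higher number judged somewhat more likely because compound 2 already sits at 275 nM, the low end of what has been seen. Compound 3 is estimated at 800 nM, within a range of 180 nM to 3500 nM, which corresponds to an expected step of a 2.9-fold higher number from compound 2 to compound 3 (0.46 log units; beyond the scatter).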

Compound 3, half-maximal inhibitory concentration: 102 nM
The estimate for compound 3 lay 7.8-fold (0.89 log units) above the measured number; the measured number lies below the stated range.
By their numbers in this assay, from the lowest: compound 3; then compound 2; then compound 1.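

In this assay, a second exchange of the aromatic group on a double-bonded chain carbon bound to a double-bonded chain carbon lowers the number further, with a 2.7-fold lower number from compound 2 to compound 3 (0.43 log units; beyond the scatter) and, measured against the first compound, a 34-fold lower number from compound 1 to compound 3 (1.54 log units; beyond the scatter). The ring nitrogen of 6-chloropyridin-3-yl is therefore not needed for a low number, and the ring of carbon only in 4-carboxyphenyl is compatible with the lowest number of the three, even though the 2,3-dimethylphenyl group of compound 1 also has a ring of carbon only and gives the highest, so the groups carried on the ring count here and not just the type of ring. No measurement is available that explains why these groups give such different numbers.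

Going by these compounds, whether the low number of compound 3 depends on the carboxylic acid itself remains open, and a methyl ester or an amide in its place would test this. A plain phenyl ring at the same place would show how much of the difference among the three compounds comes from the groups on the ring, and how much from the ring alone.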